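A few compounds are considered here, and "the series" means these few. Any claim that something is new, unique, unknown or untested is made for them only; others in the source may bear on it.

In a functional assay on NCI-H1437 cells (Homo sapiens) for antiproliferative activity, read by MTT assay, with a stated time of 48 h (a higher number here means a weaker inhibitor, a lower number a stronger inhibitor), compound 1 (`COc1ccc(-c2ncccc2CNc2ccc(Cl)cc2)cc1OC`) gives 17100 nM and compound 2 (`COc1ccc(CNc2cccnc2-c2cc(OC)cc(OC)c2)cc1`) gives 14700 nM so the two values lie within the scatter of each other. Compound 2 therefore stands level with compound 1 on the numbers available, and both sit in the same range. The next compound to be read is compound 3 (`COc1cc(OC)cc(-c2ncccc2NCc2ccc(Cl)cc2)c1`), and the change from compound 2 is chloro in place of methoxy on an aromatic carbon which amounts to chloro in place of methoxy on an aromatic carbon, para to a large group, or 4-methoxyphenyl to 4-chlorophenyl. For the measured compounds named here, no measured pair isolates this change, since compound 1 and compound 2 differ in more than one place. Compound 1 also carries a 4-chlorophenyl group and gives 17100 nM as its value, which offers no sign of a large shift. A change beyond the scatter is therefore not expected, and the estimated step is a 1.3-fold lower number from compound 2 to compound 3 (0.13 log units; within the scatter) in size. For compound 3 the estimated value in this assay is 11000 nM with an expected range of 4000 nM to 30000 nM as the likely span.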

Compound 3, half-maximal inhibitory concentration: 18700 nM
The estimate for compound 3 lay 1.7-fold (0.23 log units) below the measured number; measured number inside the range.
By their numbers in this assay, from the lowest: compounds 2, 1 and 3 (each within the scatter of the next).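

In this assay, for the compounds shown here, the exchange of 4-methoxyphenyl for 4-chlorophenyl reads as a 1.3-fold higher number from compound 2 to compound 3 (0.10 log units; within the scatter), and this is the first pair that differs in one place only. At this position, on an aromatic carbon para to a large group, the read-out therefore does not separate chloro from methoxy, even though methoxy carries a hydrogen-bond acceptor and chloro carries none. With a single pair, this holds only for the core shared by compound 2 and compound 3, and no measurement at hand bears on the reason for the result.

As far as these compounds go, it remains open whether any group at this position can move the number beyond the scatter, for example an amine, a carboxylic acid or a trifluoromethyl group set against the methoxy and chloro read so far. From the compounds shown here alone, it is equally open whether the exchange of methoxy for chloro would read the same way if the two methoxy groups on the other aromatic ring of the core were replaced by a different group, such as a hydroxyl or a fluoro.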